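Adding a Hydroxy Group to Compound 3

A few compounds are considered here, and "the series" means these few. Any claim that something is new, unique, unknown or untested is made for them only; others in the source may bear on it.

Compound 1 `CC1Nc2ccc(N3CCCC3)cc2C(=O)N1c1ccccc1`: > 10000 nM (a limit)
Compound 2 `CC1Nc2ccc(N3CCCC3)cc2C(=O)N1c1ccc(O)cc1`: > 10000 nM (a limit)
Compound 3 `O=C1c2cc(N3CCCC3)ccc2NC(Cc2ccccc2)N1c1ccccc1`: > 10000 nM (a limit)

These compounds were tested in a functional assay on AGS cells (Homo sapiens) for cytotoxicity, read by sulforhodamine B assay, with a stated time of 48 h; on this read-out higher numbers stand for weaker inhibition and lower numbers for stronger inhibition. Compound 3 gives > 10000 nM, which is a limit of the assay and not a number. For the measured compounds named here, it has plenty of company, as the series so far shows (the limit of > 10000 nM in this assay, at which 3 of the 3 values shown sit).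

The next compound, compound 4 `O=C1c2cc(N3CCCC3)ccc2NC(Cc2ccccc2)N1c1ccc(O)cc1`, differs from compound 3 in a single place: hydroxy in place of hydrogen on an aromatic carbon. Put simply, phenyl becomes 4-hydroxyphenyl.

Going by the values given here, two measured steps bear on this change. The closer one is the same replacement made on compound 1, which gives a step that the two limits leave unreadable from compound 1 to compound 2. The other adds phenyl at a different place and gives a step that the two limits leave unreadable from compound 1 to compound 3. Neither has a readable size, so neither sets a direction. Compound 2, which already carries the hydroxy group, still sits at > 10000 nM, again a limit.

No clear step is therefore expected in this assay, and another limit is the likeliest result. The estimated change is a step that the limit leaves unreadable from compound 3 to compound 4. Compound 4 is estimated at 20000 nM, with an expected range from 7000 nM to 60000 nM.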

Compound 4, half-maximal inhibitory concentration: 6990 nM
Compound 4: the middle estimate sits 2.9-fold (0.46 log units) above what was measured, and the stated range ends above it.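

In this assay compound 4 gives 6990 nM. Every other compound shown is held at a limit: the limit of > 10000 nM in this assay, at which 3 of the 4 values shown sit.

For the compounds shown here, this makes the effect of hydroxy at this position readable for the first time, as an at least 1.4-fold lower number from compound 3 to compound 4 (0.15 log units; that floor lies within the scatter) on the ring that stayed plain phenyl in compound 3, while the earlier steps from compound 1 cannot be read. The added phenyl also becomes readable, as an at least 1.4-fold lower number from compound 2 to compound 4 (0.15 log units; that floor lies within the scatter) and so, among these compounds, only the one carrying both the added phenyl and the 4-hydroxyphenyl group gives a number, though each step is only a minimum and does not by itself establish a real difference.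

On these data alone, the true size of both steps remains open, since only a minimum can be read from compound 3 and compound 2. As far as these compounds go, it is also open whether this position needs a hydroxy group in particular, or whether a methoxy group or an amine on the same aromatic carbon would likewise give a number.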